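Furan-2-yl in place of 4-methylphenyl in compound 4

The source may report more compounds than this note shows. Statements on the series, on what has been measured and on what is new or still open speak of the compounds shown alone.

Half-life in an ADME assay on cells (Hepatocyte, Homo sapiens) for metabolic stability; a lower number here means that the compound disappears faster, a higher number that the compound lasts longer:
- compound 1 `CS(=O)(=O)NC1CCC(CN2CCN(c3cc(=O)c4cc(C(F)(F)F)cc([N+](=O)[O-])c4s3)CC2)CC1`: > 1.55 h (a limit, not a number)
- compound 2 `O=c1cc(N2CCN(CC3CCC(NS(=O)(=O)c4ccccc4)CC3)CC2)sc2c([N+](=O)[O-])cc(C(F)(F)F)cc12`: > 1.55 h (a limit, not a number)
- compound 3 `Cc1ccc(C(=O)OC2CCC(CN3CCN(c4cc(=O)c5cc(C(F)(F)F)cc([N+](=O)[O-])c5s4)CC3)CC2)cc1`: 0.148 h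
- compound 4 `O=C(OC1CCC(CN2CCN(c3cc(=O)c4cc(C(F)(F)F)cc([N+](=O)[O-])c4s3)CC2)CC1)c1ccco1`: not yet measured

Among the measured compounds shown here, compound 3 holds the only actual number, 0.148 h. Compound 4 differs from it by furan-2-yl in place of 4-methylphenyl on a carbonyl carbon. Two large steps, both beyond the scatter, bear on it only indirectly: an at least 10-fold lower number from compound 1 to compound 3 (1.02 log units; beyond the scatter) and an at least 10-fold lower number from compound 2 to compound 3 (1.02 log units; beyond the scatter). Both replace the whole ((4-methylphenyl)carbonyl)oxy group, whereas compound 4 retains the carbonyl and oxygen link of compound 3. For the measured compounds named here, no measured step changes the group on the carbonyl carbon itself. In this assay, the expected change is none beyond the scatter: a 1.1-fold lower number from compound 3 to compound 4 (0.06 log units; within the scatter). For compound 4 the estimate is 0.13 h, with an expected range of 0.06 h to 0.35 h.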

Compound 4, half-life: 0.075 h
For compound 4 the middle estimate is 1.7-fold (0.24 log units) above the measured one; the range from low to high includes it.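

In this assay, the first change shown on the carbonyl carbon stays within the scatter: a 2.0-fold lower number from compound 3 to compound 4 (0.30 log units; within the scatter). The large gap to the sulfonyl-bearing compounds also holds with furan-2-yl on the carbonyl carbon: an at least 20-fold lower number from compound 2 to compound 4 (1.31 log units; beyond the scatter), and an at least 20-fold lower number from compound 1 to compound 4 (1.31 log units; beyond the scatter). Both of these steps start from a limit, not a number: the limit of > 1.55 h in this assay, at which 2 of the 4 values shown sit.

The compounds shown do not separate the carbonyl-and-oxygen link from the groups attached to it. Open, on these data alone, is where a carboxamide in place of ((furan-2-yl)carbonyl)oxy would fall in this assay.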